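The compounds below may be only part of what the source reports. "The series", "measured", "known", "first", "only" and "open" are said of these compounds alone.

Working notes on the indole azo benzamide series.

Compound 1 `Cc1ccc(NC(=O)c2ccc(/N=N\c3c[nH]c4ccccc34)cc2)cc1` serves as the reference: in a functional assay on HCT-116 cells (Homo sapiens) for inhibition, read by MTT assay, with a stated time of 72 h (a higher number here means a weaker inhibitor, a lower number a stronger inhibitor), compound 1 gives 25400 nM. Compound 2 `O=C(Nc1ccc([N+](=O)[O-])cc1)c1ccc(/N=N\c2c[nH]c3ccccc23)cc1` differs from compound 1 by nitro in place of methyl on an aromatic carbon; in this assay compound 2 gives 156000 nM, which makes the step of a 6.1-fold higher number from compound 1 to compound 2 (0.79 log units; beyond the scatter). Compound 3 `Cc1cccc(NC(=O)c2ccc(/N=N\c3c[nH]c4ccccc34)cc2)c1` differs from compound 1 by 3-methylphenyl in place of 4-methylphenyl on an amide-type nitrogen, and this is also how the core of compound 3 and compound 4 differs from the core of compound 1 and compound 2. In this assay compound 3 gives 98900 nM; the steps are a 3.9-fold higher number from compound 1 to compound 3 (0.59 log units; beyond the scatter) and a 1.6-fold lower number from compound 2 to compound 3 (0.20 log units; within the scatter).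

Compound 4 `O=C(Nc1cccc([N+](=O)[O-])c1)c1ccc(/N=N\c2c[nH]c3ccccc23)cc1` has not yet been measured. It differs from compound 3 by nitro in place of methyl on an aromatic carbon. This is the same kind of change as that from compound 1 to compound 2, not the same change: the place is meta to a large group in compound 4, where it was para to a large group in compound 2. The change has occurred once so far in the measured set.

For compound 4 a step of similar direction and size, a 3.5-fold higher number from compound 3 to compound 4 (0.55 log units; beyond the scatter), is expected, because a 6.1-fold higher number from compound 1 to compound 2 (0.79 log units; beyond the scatter) is the only measured case of this change. The expectation rests on one pair only and on a different place, so it is loosely held. The estimate for compound 4 in this assay is 350000 nM, expected to fall between 120000 nM and 1000000 nM; a limit rather than a number is a real possibility at this level.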

Compound 4, half-maximal inhibitory concentration: 70100 nM
Beside the measured number, compound 4's estimate is 5.0-fold (0.70 log units) above it; measured number below the stated range.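

Nitro in place of methyl does not carry over as a fixed step from one core to the other in this assay, as the two cases set together show: the same change on two cores in this assay, a 6.1-fold higher number (0.79 log units; beyond the scatter) from compound 1 to compound 2 and a 1.4-fold lower number (0.15 log units; within the scatter) from compound 3 to compound 4, 8.7-fold (0.94 log units) apart, beyond the scatter of two such steps

On the second core the step is a 1.4-fold lower number from compound 3 to compound 4 (0.15 log units; within the scatter), which leaves no difference to read there, while the other two steps that end at compound 4 are a 2.2-fold lower number from compound 2 to compound 4 (0.35 log units; beyond the scatter) and a 2.8-fold higher number from compound 1 to compound 4 (0.44 log units; beyond the scatter), so 3-nitrophenyl and 4-nitrophenyl can be told apart, and the core of compound 1 with its 4-methylphenyl keeps the lowest number of the four. With a single pair on each core, this shows only that the size of the change depended on the core in these four compounds; it gives no reason for the gap and no rule for any further core.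

The compounds shown leave open whether an amine, a carboxylic acid or a chlorine in the same two places would follow the methyl compounds, the nitro compounds or neither. They also leave open whether the gap between the two cores would persist with a longer chain on the ring, or in a cell line other than the one used here.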